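Swapping isopropyl for pyridinylmethyl: expected rat exposure

The source may hold more compounds than are shown below. What is called first, only, known or untested is meant among the compounds shown, and "the series" means these compounds.

Measured compounds:
compound 1 `Cc1nc(NC(C)C)nc(N[C@@H]2C[C@H](CO)[C@@H](O)[C@H]2O)c1-c1nc2ccccc2s1`: 8420 ng.h/mL
compound 2 `Cc1nc(NCCOC(C)C)nc(N[C@@H]2C[C@H](CO)[C@@H](O)[C@H]2O)c1-c1nc2ccccc2s1`: 426 ng.h/mL
compound 3 `CCOC(=O)NCCNc1nc(C)c(-c2nc3ccccc3s2)c(N[C@@H]2C[C@H](CO)[C@@H](O)[C@H]2O)n1`: 151 ng.h/mL

In an ADME assay on the whole organism (plasma) for pharmacokinetics, with Rattus norvegicus as the target, with a stated time of 6 h, at a dose of 10 mg/kg by the oral route (on this read-out lower numbers stand for lower exposure and higher numbers for higher exposure at the dose given), compound 1 stands highest of the three numbers, with compound 2 and compound 3 well below it. Compound 4 `Cc1nc(NCc2ccncc2)nc(N[C@@H]2C[C@H](CO)[C@@H](O)[C@H]2O)c1-c1nc2ccccc2s1` differs from compound 1 by (pyridin-4-yl)methyl in place of isopropyl on a nitrogen on an aromatic ring. For the measured compounds named here, two measured steps bear on this, each replacing the same isopropyl on a nitrogen on an aromatic ring with a different group: a 20-fold lower number from compound 1 to compound 2 (1.30 log units; beyond the scatter) and a 56-fold lower number from compound 1 to compound 3 (1.75 log units; beyond the scatter). Both steps were large drops beyond the scatter. Since compound 4 replaces that same isopropyl, a downward step beyond the scatter is expected, a 14-fold lower number from compound 1 to compound 4 (1.15 log units; beyond the scatter). Compound 4 is therefore estimated at 600 ng.h/mL, expected to fall between 150 ng.h/mL and 2500 ng.h/mL.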

Compound 4, area under the concentration-time curve: 47.9 ng.h/mL
The estimate for compound 4 lay 13-fold (1.10 log units) above the measured number, outside the stated range (below it).
By their numbers in this assay, from the lowest: compound 4; then compound 3; then compound 2; then compound 1.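

In this assay, (pyridin-4-yl)methyl on this nitrogen gives the largest drop seen so far, a 180-fold lower number from compound 1 to compound 4 (2.24 log units; beyond the scatter), so replacing isopropyl here can cost more than either open chain did. Compound 4 also falls under both chain compounds, with a 3.2-fold lower number from compound 3 to compound 4 (0.50 log units; beyond the scatter) and an 8.9-fold lower number from compound 2 to compound 4 (0.95 log units; beyond the scatter), so the chains did not mark the lowest level for this position. No measurement shown accounts for this drop.

Benzyl, which has carbon in place of the ring nitrogen, would help separate the effect of the ring from that of its nitrogen. Small alkyl groups such as ethyl or cyclopropyl would show whether exposure stays close to that of compound 1.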